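The compounds below may be only part of what the source reports. "The series", "measured", "known", "first", "only" and "open" are said of these compounds alone.

Compound 1 `Nc1nc(OCc2cccc(F)c2)c2nn[nH]c2n1` gives 40 nM in an assay on isolated protein for inhibition of Myeloperoxidase (Homo sapiens), read by fluorescence, with stated times of 10 min, 30 s and 5 min; on this read-out lower numbers stand for stronger inhibition and higher numbers for weaker inhibition.
Compound 2 `Nc1nc(OCc2cccc(Cl)c2)c2nn[nH]c2n1` gives 200 nM in this assay.
Compound 3 `COc1cccc(COc2nc(N)nc3[nH]nnc23)c1` gives 490 nM in this assay.

Compound 3 stands highest of the three numbers; the measured steps read a 12-fold higher number from compound 1 to compound 3 (1.09 log units; beyond the scatter) and a 2.5-fold higher number from compound 2 to compound 3 (0.39 log units; beyond the scatter), both beyond the scatter. Compound 4 `Nc1nc(OCc2cccc(OC(F)F)c2)c2nn[nH]c2n1` differs from compound 3 by difluoromethyl in place of methyl on an oxygen on an aromatic ring. Going by the values given here, the measured steps all exchange the substituent on the aromatic carbon; none of them alters the group on that oxygen, so they bear on this step only indirectly, and no measured pair resembles it closely. A modest step is expected rather than a large one. This estimate means an expected step of a 2.0-fold lower number from compound 3 to compound 4 (0.29 log units; within the scatter). Compound 4 is therefore expected to give about 250 nM in this assay, within a range from 80 nM to 800 nM.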

Compound 4, half-maximal inhibitory concentration: 200 nM
Estimate against measurement, compound 4: 1.3-fold (0.10 log units) above, within the range that was stated.
By their numbers in this assay, from the lowest: compound 1; then compounds 2 and 4 (each within the scatter of the next); then compound 3.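

Going by these compounds alone, replacing the group on the oxygen, which no earlier step touched, shifts the number in this assay: difluoromethyl in place of methyl gives a 2.5-fold lower number from compound 3 to compound 4 (0.39 log units; beyond the scatter). Difluoromethoxy in place of chloro gives no change at the digits printed from compound 2 to compound 4 (within the scatter), while difluoromethoxy in place of fluoro gives a 5.0-fold higher number from compound 1 to compound 4 (0.70 log units; beyond the scatter), so compound 1 keeps the lowest number of the four. No evidence given here explains these differences.

The compounds shown leave open how trifluoromethyl or ethyl on that oxygen would read. They also leave open how an amine or a carboxylic acid on the aromatic carbon would read.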